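A few compounds are considered here, and "the series" means these few. Any claim that something is new, unique, unknown or untested is made for them only; others in the source may bear on it.

Series notes. Compound 1 `Cc1cc(NC(=O)Nc2cc(F)ccc2F)c2ccccc2n1` and compound 2 `Cc1cc(NC(=O)Nc2cccc(C(N)=O)c2)c2ccccc2n1` share one core. In an ADME assay on HepG2 cells (Homo sapiens) for cytotoxicity, with a stated time of 72 h (a higher number here means that more compound is needed for the effect, a lower number that less compound is needed), compound 1 gives only a limit, > 25000 nM. In this assay compound 2 also gives only a limit, > 25000 nM. Both values sit at the limit of > 25000 nM in this assay, at which 2 of the 2 values shown sit, so compound 2 cannot be placed against compound 1 on these numbers. Compound 3 `COc1cccc(NC(=O)Nc2cc(C)nc3ccccc23)c1` differs from compound 2 by methoxy in place of carbamoyl on an aromatic carbon. For the measured compounds named here, no measured step covers this change; the expected step that the limit leaves unreadable from compound 2 to compound 3 is none beyond the scatter, most likely another limit. The estimate for compound 3 in this assay is 30000 nM, between 15000 nM and 60000 nM.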

Compound 3, half-maximal effective concentration: > 25000 nM
Compound 3 gave a limit, no number; the forecaster's own chance of this, stated with the estimate: 85%; the middle value does not contradict the limit.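

No step from compound 2 to compound 3 can be read, because both compounds give only a limit: the limit of > 25000 nM in this assay, at which 3 of the 3 values shown sit.

The compounds shown leave open whether any change on the shared core shifts the half-maximal effective concentration in this assay.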